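Chloro for trifluoromethyl on a hydroxychalcone

The compounds below may be only part of what the source reports. "The series", "measured", "known", "first", "only" and "open" are said of these compounds alone.

Measured so far:
compound 1, `O=C(/C=C/c1ccc(C(F)(F)F)cc1)c1ccccc1O`: 85.1%
compound 2, `O=C(/C=C/c1cccc(Br)c1)c1ccccc1O`: 29.6%

In a functional assay on HCT-116 cells (Homo sapiens) for cytotoxicity, read by MTT assay, with a stated time of 48 h, tested at 15 uM (a lower number here means a stronger effect, a higher number a weaker effect of the compound at the concentration tested), compound 1 gives 85.1%, the highest of the two numbers and thus the weaker effect; compound 2 lies lower by a gap beyond the scatter. Compound 3, `O=C(/C=C/c1ccc(Cl)cc1)c1ccccc1O`, is not yet measured. It differs from compound 1 by chloro in place of trifluoromethyl on an aromatic carbon. Within the data shown here, no step between measured compounds shows what this exchange does, so the expectation rests on the two numbers alone. Compound 3 is expected to move downward from compound 1, a step of a number 25.1 percentage points lower from compound 1 to compound 3 (beyond the scatter) in this assay. The estimate for compound 3 is 60%, within 25% to 95%.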

Compound 3, a percentage reported as activity, at one concentration (the size of the read-out at that concentration, not a potency): 69.1%
Estimate against measurement, compound 3: 9.1 percentage points below, and the stated range covers the measured number.
By their numbers in this assay, from the lowest: compound 2; then compound 3; then compound 1.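

In this assay, chloro in place of trifluoromethyl on this aromatic carbon gives a number 16 percentage points lower from compound 1 to compound 3 (beyond the scatter), so the effect of the compound at the tested concentration becomes stronger. Among these compounds, this is the first direct reading of this exchange, in which a single heavy atom replaces a group of four while the rest of the core stays the same. Nothing measured here says why the number moves.

Still open, going by these compounds, is how an amine or a methoxy group on this same carbon would compare with chloro and trifluoromethyl. Also open, on these data alone, is whether the same exchange gives a similar step on another core.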